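This account rests on a few compounds, and the source may have more. Where it says the series, first, only, none or still open, it means among the compounds named here.

Compound 1, `COc1ccc(Cl)cc1C(C)NC(=O)N(C)S(=O)(=O)c1ccc(C)cc1`, gives 13800 nM in a functional assay on thoracic aorta (Rattus norvegicus, strain Wistar), with a stated time of 15 min; on this read-out lower numbers stand for an effect already at smaller amounts and higher numbers for an effect only at larger amounts of compound.
Compound 2, `COc1ccc(Cl)cc1C(C)NC(=O)N(C)S(=O)(=O)c1ccccc1`, gives 7200 nM in this assay.
Compound 3, `CC(NC(=O)N(C)S(=O)(=O)c1ccc(Cl)cc1)c1ccccc1OCc1ccccc1`, gives 38400 nM in this assay.

Compound 4, `Cc1ccc(OCc2ccccc2)c(C(C)NC(=O)N(C)S(=O)(=O)c2ccc(Cl)cc2)c1`, has not yet been measured. It differs from compound 3 by methyl in place of hydrogen on an aromatic carbon. The same kind of change has been measured once already, between compound 2 and compound 1, where it reads methyl in place of hydrogen on an aromatic carbon and amounts to a 1.9-fold higher number from compound 2 to compound 1 (0.28 log units; within the scatter). The two places are not alike, however: in compound 1 the methyl sits para to a large group, whereas in compound 4 it sits meta to a large group and para to a benzyloxy group, so the two are the same kind of change rather than the same change. How the core of compound 3 differs from that of compound 2 is not broken down here; compound 3 simply stands highest of the three numbers in this assay. Because a 1.9-fold higher number from compound 2 to compound 1 (0.28 log units; within the scatter), only a small step in this assay is expected here as well, a 1.2-fold higher number from compound 3 to compound 4 (0.07 log units; within the scatter). Compound 4 is therefore estimated at 45000 nM, with a range from 15000 nM to 130000 nM.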

Compound 4, half-maximal effective concentration: 142000 nM
Compound 4: the middle estimate sits 3.2-fold (0.50 log units) below what was measured; measured number outside the range, above it.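

In this assay, putting methyl in place of hydrogen on an aromatic carbon of the core of compound 3 gives a 3.7-fold higher number from compound 3 to compound 4 (0.57 log units; beyond the scatter), so on this core the change moves the number by more than the usual scatter. Set beside the earlier step, this one cannot be told apart from it, so the change may carry from one core to the other with a similar size: the same change on two cores in this assay, a 1.9-fold higher number (0.28 log units; within the scatter) from compound 2 to compound 1 and a 3.7-fold higher number (0.57 log units; beyond the scatter) from compound 3 to compound 4, 1.9-fold (0.29 log units) apart, within the scatter of two such steps.
For the compounds shown here, this does not show that the step is constant across the series, since it rests on only two pairs, the earlier of which lies within the scatter by itself, and the methyl does not stand in the same place on the two cores.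

At these positions the compounds shown carry only hydrogen or methyl, so it remains open how a longer chain such as ethyl, an amine or a carboxylic acid would read in this assay. On these data alone, whether the methyl step would hold on a third core also remains open.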